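Amide-aryl exchange in a three-compound antiproliferative series

The compounds below may be only part of what the source reports. "The series", "measured", "known", "first", "only" and "open" are said of these compounds alone.

Compound 3 `CCc1ccc(C(=O)Nc2cccc(-c3oc4cc(-c5ccc(F)cc5)ccc4c(=O)c3O)c2)cc1` stands at the high end of the three numbers in hand: in a functional assay on MCF7 cells (Homo sapiens) for antiproliferative activity, read by CCK-8 assay, with a stated time of 72 h (on this read-out higher numbers stand for weaker inhibition and lower numbers for stronger inhibition), compound 3 gives 22800 nM. Compound 1 `O=C(Nc1cccc(-c2oc3cc(-c4ccc(F)cc4)ccc3c(=O)c2O)c1)c1ccc(F)cc1` gives 8590 nM in this assay, and compound 2 `COc1cccc(C(=O)Nc2cccc(-c3oc4cc(-c5ccc(F)cc5)ccc4c(=O)c3O)c2)c1` gives 15300 nM. Among the steps between them, a 2.7-fold higher number from compound 1 to compound 3 (0.42 log units; beyond the scatter) lies beyond the scatter, whereas a 1.8-fold higher number from compound 1 to compound 2 (0.25 log units; within the scatter) and a 1.5-fold higher number from compound 2 to compound 3 (0.17 log units; within the scatter) do not.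

Compound 4 `O=C(Nc1cccc(-c2oc3cc(-c4ccc(F)cc4)ccc3c(=O)c2O)c1)c1ccc(Cl)nc1` differs from compound 3 by 6-chloropyridin-3-yl in place of 4-ethylphenyl on a carbonyl carbon. The step bearing most directly on this is a 2.7-fold higher number from compound 1 to compound 3 (0.42 log units; beyond the scatter): the group entering in compound 4 carries a halogen, as does the 4-fluorophenyl of compound 1, while the 4-ethylphenyl that leaves is the one whose arrival gave the higher number. The step of a 1.5-fold higher number from compound 2 to compound 3 (0.17 log units; within the scatter) shows that exchanging one six-membered aromatic group on the carbonyl carbon for another need not move the number beyond the scatter. Taken together, the number for compound 4 in this assay is expected to fall back toward that of compound 1, a step of a 2.3-fold lower number from compound 3 to compound 4 (0.36 log units; beyond the scatter), though an outcome within the scatter of compound 3 cannot be ruled out. Compound 4 is estimated at 10000 nM, with a range from 4000 nM to 25000 nM.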

Compound 4, half-maximal inhibitory concentration: 2890 nM
Beside the measured number, compound 4's estimate is 3.5-fold (0.54 log units) above it; measured number outside the range, below it.
By their numbers in this assay, from the lowest: compound 4; then compounds 1, 2 and 3 (each within the scatter of the next, the first and the last beyond it).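

On the carbonyl carbon of the amide, 6-chloropyridin-3-yl gives the strongest inhibition of the four compounds in this assay, and the exchange moves the number beyond the scatter against each earlier group (a 7.9-fold lower number from compound 3 to compound 4 (0.90 log units; beyond the scatter); a 5.3-fold lower number from compound 2 to compound 4 (0.72 log units; beyond the scatter); a 3.0-fold lower number from compound 1 to compound 4 (0.47 log units; beyond the scatter)). Among the earlier compounds, the widest step at this place was smaller (a 2.7-fold higher number from compound 1 to compound 3 (0.42 log units; beyond the scatter)), so this place allows a larger change in the number than the three phenyl-bearing amides had shown, and in the direction of stronger inhibition. Nothing in hand accounts for the lower number of compound 4.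

On these data alone, the exchange brings in a ring nitrogen and a chlorine together, so the share of each in the step stays open; 4-chlorophenyl and unsubstituted pyridin-3-yl on the same carbonyl carbon would separate them. Also open, as far as these compounds go, is whether the chlorine of the 6-chloropyridin-3-yl group can give way to a methoxy group or an amine, and whether any of these steps carries over to cell lines other than MCF7.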